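This account rests on a few compounds, and the source may have more. Where it says the series, first, only, none or still open, it means among the compounds named here.

Working notes on the series. Compound 1 is `CC(C)(C)Oc1ccc2nc(N)sc2c1`. In a functional assay on the whole organism with Rattus norvegicus as the target (on this read-out lower numbers stand for an effect already at smaller amounts and higher numbers for an effect only at larger amounts of compound), compound 1 gives only a limit, > 10 mg/kg, and so stands apart from the others in having no number of its own (the limit of > 10 mg/kg in this assay, at which 1 of the 3 values shown sits). Compound 2, `CCCc1ccc2nc(N)sc2c1`, gives 6 mg/kg in this assay. Compound 3, `CCCCCc1ccc2nc(N)sc2c1`, gives 7.5 mg/kg in this assay. The steps of an at least 1.6-fold lower number from compound 1 to compound 2 (0.22 log units; that floor lies within the scatter) and an at least 1.3-fold lower number from compound 1 to compound 3 (0.12 log units; that floor lies within the scatter) are floors read off a limit and say little about their true size; the step of a 1.3-fold higher number from compound 2 to compound 3 (0.10 log units; within the scatter) lies within the scatter.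

Compound 4 is `Nc1nc2ccc(OCC(F)(F)F)cc2s1`. The change from compound 1 is 2,2,2-trifluoroethyl in place of tert-butyl on an oxygen on an aromatic ring: the tert-butyl leaves, the 2,2,2-trifluoroethyl enters, the oxygen on the aromatic ring stays. For the measured compounds named here, no measured step swaps one group for another on that oxygen; both steps that start from compound 1 remove the whole tert-butoxy group for a chain, so they bear on the present change only loosely, and their floors lie within the scatter. The direction is therefore open, and a step beyond the scatter is not expected with any confidence; a further limit is about as likely as a number. Compound 4 is expected near 10 mg/kg, within 4 mg/kg to 25 mg/kg, the expected step being a number no higher from compound 1 to compound 4 (the limit leaves the size open).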

Compound 4, dose for half-maximal effect: 6.5 mg/kg
The estimate for compound 4 lay 1.5-fold (0.19 log units) above the measured number, and the stated range covers the measured number.
By their numbers in this assay, from the lowest: compounds 2, 4 and 3 (each within the scatter of the next). At a limit, above all of these: compound 1.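

Compound 4 shows that a compound keeping the oxygen on the aromatic ring can give a number in this assay, whereas the earlier numbers came only from propyl and pentyl chains standing in place of the whole tert-butoxy group. Exchanging only the group on that oxygen gives an at least 1.5-fold lower number from compound 1 to compound 4 (0.18 log units; that floor lies within the scatter), so the step is a floor and does not establish a real difference between the two groups. Its true size stays unknown because compound 1 stands at a limit: the limit of > 10 mg/kg in this assay, at which 1 of the 4 values shown sits.

The compounds shown leave open whether the number of compound 4 is particular to the 2,2,2-trifluoroethyl group or would hold for other groups on that oxygen, such as a plain ethyl, a methyl or a 2-methoxyethyl. Also open, going by these compounds, is how a group carrying an amine or a carboxylic acid at the end of a chain on that oxygen would read out in this assay.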